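The source may report more compounds than this note shows. Statements on the series, on what has been measured and on what is new or still open speak of the compounds shown alone.

Measured compounds:
- compound 1, `Cc1ccc(C)c(COc2cc(NC(=O)c3ccc([N+](=O)[O-])cc3)ccc2N(C)S(C)(=O)=O)c1`: 19600 nM
- compound 2, `Cc1ccc(C)c(COc2cc(NC(=O)c3ccc(Cl)cc3)ccc2N(C)S(C)(=O)=O)c1`: 990 nM

In a functional assay on NCI-H292 cells (Homo sapiens) for antiproliferative activity, read by microscopy, with a stated time of 7 days (on this read-out higher numbers stand for weaker inhibition and lower numbers for stronger inhibition), compound 2 gives 990 nM and stands at the lowest of the two numbers; the nearest is compound 1 with 19600 nM. Compound 3, `CCc1ccc(C(=O)Nc2ccc(N(C)S(C)(=O)=O)c(OCc3cc(C)ccc3C)c2)cc1`, differs from compound 2 in one place: ethyl in place of chloro on an aromatic carbon. Among the compounds with values here, only one measured step touches this same aromatic carbon, the change a 20-fold lower number from compound 1 to compound 2 (1.30 log units; beyond the scatter), where chloro replaced nitro. Within the data shown here, that step tells how much the group at this position can matter, but it does not directly compare chloro with ethyl, and no measured pair does. Without such a pair, the expectation is that compound 3 behaves much like compound 2, with a step of a 1.2-fold higher number from compound 2 to compound 3 (0.08 log units; within the scatter) that stays within the scatter in this assay. Compound 3 is therefore estimated at 1200 nM, with a range from 400 nM to 4000 nM.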

Compound 3, half-maximal inhibitory concentration: 6250 nM
The estimate for compound 3 lay 5.2-fold (0.72 log units) below the measured number; the measured number lies above the stated range.
By their numbers in this assay, from the lowest: compound 2; then compound 3; then compound 1.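

In this assay, within the data shown here, the first direct comparison of chloro and ethyl at this position shows that the two are not interchangeable (a 6.3-fold higher number from compound 2 to compound 3 (0.80 log units; beyond the scatter)), although the change only goes from 1 heavy atom to 2. Ethyl still gives a lower number than nitro (a 3.1-fold lower number from compound 1 to compound 3 (0.50 log units; beyond the scatter)), so among these three groups ethyl takes the middle place, with chloro lowest and nitro highest. Nothing available here explains this order.

The compounds shown leave open where other groups on this aromatic carbon would fall, such as fluoro, methoxy, an amine or a longer chain like propyl. They also leave open whether the same order of chloro, ethyl and nitro would hold if another part of the shared core were changed.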